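Azetidine urea replacing glycinamide on the piperidine nitrogen

The source may hold more compounds than are shown below. What is called first, only, known or untested is meant among the compounds shown, and "the series" means these compounds.

Measured so far:
compound 1 `CCOC(=O)N1CCC(NS(=O)(=O)c2ccc(O)c3ccccc23)CC1` > 5000 nM
compound 2 `Cc1ccccc1C(=O)Nc1ccc(S(=O)(=O)NC2CCN(C(=O)CN)CC2)c2ccccc12` 4.1 nM

Within the data shown here, in an assay on L1.2 cells for binding affinity to C-C chemokine receptor type 8 (Homo sapiens) (on this read-out lower numbers stand for stronger inhibition and higher numbers for weaker inhibition), compound 2 gives 4.1 nM, the only number in the set. Compound 1 sits at a limit of the assay, (the limit of > 5000 nM in this assay, at which 1 of the 2 values shown sits), not a number. Compound 3 `Cc1ccccc1C(=O)Nc1ccc(S(=O)(=O)NC2CCN(C(=O)N3CCC3)CC2)c2ccccc12` differs from compound 2 in one place: azetidin-1-yl in place of aminomethyl on a carbonyl carbon. Among the measured compounds shown here, no step between measured compounds is available, so the expectation rests on this change alone. A modest weakening is expected, a 2.9-fold higher number from compound 2 to compound 3 (0.47 log units; beyond the scatter), beyond the scatter but small. Compound 3 is estimated at 12 nM, in the range 4 nM to 40 nM.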

Compound 3, inhibition constant: 3.5 nM
Beside the measured number, compound 3's estimate is 3.4-fold (0.54 log units) above it, and the stated range ends above it.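

In this assay, azetidin-1-yl in place of aminomethyl on a carbonyl carbon gives a 1.2-fold lower number from compound 2 to compound 3 (0.07 log units; within the scatter). The two groups cannot be told apart on this read-out, even though aminomethyl carries 1 hydrogen-bond donor and azetidin-1-yl carries 0, so a primary amine is not required at this position for a low nanomolar value. Nothing measured here bears on the reason for this result. From the compounds shown here alone, whether a larger ring such as pyrrolidin-1-yl, a carboxylic acid or a longer aminoalkyl chain on the same carbonyl carbon would also hold the value remains open.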